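The compounds below may be only part of what the source reports. "The series", "measured", "known", "first", "only" and "open" are said of these compounds alone.

Compound 2 `CCCCCCn1c(N2CCN(C)CC2)nc2ccccc21` gives 26 nM in a functional assay on ileum for inhibition of histamine H1 receptor (Cavia porcellus) (a higher number here means a weaker inhibitor, a lower number a stronger inhibitor), the lowest of the two numbers shown. Compound 1 `CCCCCCCn1c(N2CCN(C)CC2)nc2ccccc21` gives 150 nM in this assay, and the change from compound 1 to compound 2 brought a 5.8-fold lower number from compound 1 to compound 2 (0.76 log units; beyond the scatter). Compound 3 `CCCCCCCCCCn1c(N2CCN(C)CC2)nc2ccccc21` carries butyl in place of hydrogen on a saturated chain carbon, six bonds along the chain from an aromatic nitrogen, lengthening the same chain in the direction that weakened compound 1. For the measured compounds named here, the only step that bears on it points that way, and a larger extension is expected to weaken inhibition further, so a step of a 35-fold higher number from compound 2 to compound 3 (1.54 log units; beyond the scatter) is expected in this assay. Compound 3 is therefore estimated at 900 nM, between 150 nM and 5000 nM.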

Compound 3, half-maximal inhibitory concentration: 4200 nM
For compound 3 the middle estimate is 4.7-fold (0.67 log units) below the measured one, and the stated range covers the measured number.
By their numbers in this assay, from the lowest: compound 2; then compound 1; then compound 3.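

In this assay, butyl in place of hydrogen gives a 160-fold higher number from compound 2 to compound 3 (2.21 log units; beyond the scatter) at this position, six bonds along the chain from an aromatic nitrogen, while propyl in place of hydrogen, seven bonds along the chain, gives a 28-fold higher number from compound 1 to compound 3 (1.45 log units; beyond the scatter) as a further rise. The weakening seen with the first added methyl therefore continues with greater chain length, and none of the three compounds goes against this. Nothing shown here gives a reason for this trend.

As far as these compounds go, whether a shorter chain such as propyl would lower the number further remains open. So does the effect of an amine or a carboxylic acid on this chain.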